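A few compounds are considered here, and "the series" means these few. Any claim that something is new, unique, unknown or untested is made for them only; others in the source may bear on it.

In a functional assay on BGC-823 cells (Homo sapiens) for inhibition, read by MTT assay, with a stated time of 72 h (a higher number here means a weaker inhibitor, a lower number a stronger inhibitor), compound 1 `Cc1cc(N2CC[C@@H](C)[C@@H](N(C)c3ncnc4[nH]ccc34)C2)n2nc(SCc3ccc(C(F)(F)F)cc3)nc2n1` gives 23300 nM, the lowest of the two numbers shown. Compound 3 `CCc1cc(N2CC[C@@H](C)[C@@H](N(C)c3ncnc4[nH]ccc34)C2)n2ncnc2n1` gives 82200 nM, a higher number that lies beyond the usual scatter. Compound 2 `C[C@@H]1CCN(c2cc(-c3ccccc3)nc3ncnn23)C[C@@H]1N(C)c1ncnc2[nH]ccc12` reaches only the limit of this assay, > 100000 nM (the limit of > 100000 nM in this assay, at which 1 of the 3 values shown sits). Within the data shown here, the single measured step, an at least 1.2-fold lower number from compound 2 to compound 3 (0.08 log units; that floor lies within the scatter), swaps ethyl for phenyl on an aromatic carbon and starts from a limit, so its size is only a floor. Compound 4 `Cc1cc(N2CC[C@@H](C)[C@@H](N(C)c3ncnc4[nH]ccc34)C2)n2nc(SCc3ccc(Cl)cc3)nc2n1` differs from compound 1 at the far end of the benzylsulfanyl arm: chloro in place of trifluoromethyl on an aromatic carbon. Among the measured compounds shown here, no measured step touches that arm, so no direction in this assay can be read from the data. Compound 4 is therefore expected to sit close to its parent, the estimated step being a 1.0-fold lower number from compound 1 to compound 4 (0.01 log units; within the scatter). The estimate for compound 4 is 23000 nM, within 8000 nM to 70000 nM.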

Compound 4, half-maximal inhibitory concentration: 26300 nM
Compound 4: middle estimate off by 1.1-fold (0.06 log units), on the low side; the measured number falls inside the stated range.
By their numbers in this assay, from the lowest: compounds 1 and 4 (each within the scatter of the next); then compound 3. At a limit, above all of these: compound 2.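

In this assay chloro in place of trifluoromethyl, on an aromatic carbon para to a large group, gives a 1.1-fold higher number from compound 1 to compound 4 (0.05 log units; within the scatter) and the two compounds cannot be told apart. Among these compounds, this is the first measured step at this position, and it shows that one chlorine atom can replace the four heavy atoms of trifluoromethyl with no change beyond the scatter. Nothing shown here explains this result. Going by these compounds, whether the position accepts other kinds of group stays open: a primary amine or a carboxylic acid there could give a quite different number.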